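The source may report more compounds than this note shows. Statements on the series, on what has been measured and on what is new or still open speak of the compounds shown alone.

The series shares the core of compound 1 `O=C(NCc1ccc(F)cc1)c1nc(Br)c2cccnc2c1NCc1ccccc1`; in a functional assay on MDA-MB-435 cells (Homo sapiens) for cytotoxicity, read by MTT assay, with a stated time of 72 h (on this read-out lower numbers stand for stronger inhibition and higher numbers for weaker inhibition), compound 1 gives > 20000 nM, which is a limit of the assay and not a number. Compound 2 `C[C@@H](CO)Nc1nc(C(=O)NCc2ccc(F)cc2)c(O)c2ncccc12` gives > 20000 nM in this assay, again a limit. Among the measured compounds shown here, compound 3 `Nc1ccc(Nc2c(C(=O)NCc3ccc(F)cc3)nc(Br)c3cccnc23)cc1` is the only member with a number: in this assay compound 3 gives 7000 nM. The other two values are limits, sitting at the limit of > 20000 nM in this assay, at which 2 of the 3 values shown sit. For the measured compounds named here, the one measured step, an at least 2.8-fold lower number from compound 1 to compound 3 (0.45 log units; beyond the scatter), is the only guide available. Compound 4 `CNCCCNc1c(C(=O)NCc2ccc(F)cc2)nc(Br)c2cccnc12` differs from compound 3 in one place: 3-(methylamino)propyl in place of 4-aminophenyl on a nitrogen on an aromatic ring. Going by the values given here, no measured step covers a change of this kind; the step from compound 1 to compound 3 replaced benzyl by 4-aminophenyl and says nothing direct about a chain in that place. For compound 4 the step of a 1.1-fold higher number from compound 3 to compound 4 (0.06 log units; within the scatter) is therefore expected to be small, with its direction left open. Compound 4 is estimated at 8000 nM in this assay, within 2000 nM to 20000 nM, and a limit rather than a number remains a real possibility.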

Compound 4, half-maximal inhibitory concentration: 11000 nM
For compound 4 the middle estimate is 1.4-fold (0.14 log units) below the measured one, and the stated range covers the measured number.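

A group with no ring on this nitrogen still gives a number in this assay: the step is a 1.6-fold higher number from compound 3 to compound 4 (0.20 log units; within the scatter), so 3-(methylamino)propyl and 4-aminophenyl cannot be told apart here. Against the benzyl group, the step is an at least 1.8-fold lower number from compound 1 to compound 4 (0.25 log units; that floor lies within the scatter); it rests on a limit, so its true size stays unfixed. The series still sits largely at the limit of the assay: the limit of > 20000 nM in this assay, at which 2 of the 4 values shown sit.

As far as these compounds go, whether a longer chain, a terminal primary amine or a terminal carboxylic acid on this nitrogen would shift the number beyond the scatter remains open. Also open, from the compounds shown here alone, is whether a dimethylamino end or a substituted phenyl other than 4-aminophenyl would give a number clearly apart from those of compound 3 and compound 4.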